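Moving One Fluorine on the Benzyl Group

The compounds below may be only part of what the source reports. "The series", "measured", "known", "first", "only" and "open" are said of these compounds alone.

Compound 2 `COc1ccc(S(=O)(=O)N(Cc2cc(F)cc(F)c2)[C@H](C)C(=O)NO)cc1` gives 140 nM in an assay on isolated protein for inhibition of bone morphogenetic protein 1 (Homo sapiens) (on this read-out higher numbers stand for weaker inhibition and lower numbers for stronger inhibition), and compound 1 `COc1ccc(S(=O)(=O)N(CCn2cccc2)[C@H](C)C(=O)NO)cc1` gives 170 nM; the step of a 1.2-fold lower number from compound 1 to compound 2 (0.08 log units; within the scatter) lies within the scatter, so the two stand together on the numbers shown so far. Compound 3 `COc1ccc(S(=O)(=O)N(Cc2ccc(F)c(F)c2)[C@H](C)C(=O)NO)cc1` differs from compound 2 by 3,4-difluorophenyl in place of 3,5-difluorophenyl on a saturated chain carbon bound to a sulfonamide nitrogen. Among the compounds with values here, no measured step bears directly on this change: the only step known, from compound 1 to compound 2, swaps out the entire group on that carbon rather than shifting a fluorine around the ring, and it was small. Since the two difluorophenyl arrangements share every atom, the step of no change at the digits printed from compound 2 to compound 3 (within the scatter) is expected to remain within the scatter, with no direction favored. Compound 3 is therefore estimated at 140 nM in this assay, with a range from 60 nM to 350 nM.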

Compound 3, half-maximal inhibitory concentration: 76 nM
For compound 3 the middle estimate is 1.8-fold (0.27 log units) above the measured one; the measured number falls inside the stated range.
By their numbers in this assay, from the lowest: compounds 3, 2 and 1 (each within the scatter of the next, the first and the last beyond it).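

The fluorine shift gives a 1.8-fold lower number from compound 2 to compound 3 (0.27 log units; within the scatter) in this assay and so stays within the scatter: at this position the 3,5-difluorophenyl and 3,4-difluorophenyl groups stand together on these numbers. Within the data shown here, the (1H-pyrrol-1-yl)methyl group, which could not be separated from 3,5-difluorophenyl, now has a first step beyond the scatter in a 2.2-fold lower number from compound 1 to compound 3 (0.35 log units; beyond the scatter) and this step is modest, though compound 2 still lies within the scatter of both neighbours. No supporting evidence is available to account for these readings.

The compounds shown leave open whether either fluorine matters, since an unsubstituted benzyl or a 4-fluorobenzyl group would be needed to tell. They also leave open how a chlorine, a methoxy group or a carboxylic acid on that ring would read.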